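A few compounds are considered here, and "the series" means these few. Any claim that something is new, unique, unknown or untested is made for them only; others in the source may bear on it.

Compound 1 `CCc1nc2ccccc2c(=O)n1NC(=O)Nc1ccc(Br)cc1` gives 54% in a functional assay on the whole organism (strain albino) with Mus musculus as the target, at a dose of 100 mg/kg by the intraperitoneal route; a higher number here means more inhibition at the dose given (going by the name of the read-out), a lower number less inhibition. Compound 2 `Cc1ccccc1NC(=O)Nn1c(-c2ccccc2)nc2ccccc2c1=O` gives 59%.

Compound 2 holds the higher of the two numbers, but compound 1 sits only a few points away, a gap within the usual scatter, so the two cannot be told apart. Compound 3 `CCc1nc2ccccc2c(=O)n1NC(=O)Nc1ccccc1C` differs from compound 2 in one place: ethyl in place of phenyl on an aromatic carbon. For the measured compounds named here, no measured pair shows this change, yet compound 1 also carries ethyl there and gives 54%, close to compound 2. The step is therefore expected to stay within the scatter: a number 4 percentage points lower from compound 2 to compound 3 (within the scatter). Compound 3 is estimated at 55%, between 40% and 70%.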

Compound 3, a percentage reported as inhibition, in the whole organism at one dose (the size of the read-out at that dose, not a potency): 54%
Compound 3: the middle estimate sits 1 percentage points above what was measured, and the stated range covers the measured number.
By their numbers in this assay, from the lowest: compounds 1, 3 and 2 (each within the scatter of the next).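

In this assay, for the compounds shown here, ethyl in place of phenyl on an aromatic carbon between two ring nitrogen atoms gives a number 5 percentage points lower from compound 2 to compound 3 (within the scatter) and so provides the first direct comparison at this position: the two groups cannot be told apart here. A second direct comparison, 2-methylphenyl in place of 4-bromophenyl on an amide-type nitrogen, gives no change at the digits printed from compound 1 to compound 3 (within the scatter) and likewise separates nothing. As far as these compounds go, whether an amine or a longer chain at the first position would keep the number in this range remains open. Nothing available explains these numbers.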